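Compound 3: one aromatic ring exchanged

The source may report more compounds than this note shows. Statements on the series, on what has been measured and on what is new or still open speak of the compounds shown alone.

In a functional assay on SW-620 cells (Homo sapiens) for antiproliferative activity, read by MTT assay, with a stated time of 72 h (a lower number here means a stronger inhibitor, a higher number a weaker inhibitor), compound 2 `COc1ccccc1/C=C1\CCC/C(=C\c2cc(OC)c(OC)c(OC)c2)C1=O` gives 2000 nM. Compound 1 `COc1cc(/C=C2\CCC/C(=C\c3ccccc3Br)C2=O)cc(OC)c1OC` gives 3300 nM, so the two cannot be told apart. Compound 3 `COc1cc(/C=C2\CCC/C(=C\c3ccc(O)c(Cl)c3)C2=O)cc(OC)c1OC` has 3-chloro-4-hydroxyphenyl in place of 2-methoxyphenyl on a double-bonded chain carbon bound to a double-bonded ring carbon. Among the compounds with values here, one measured step bears on this ring: methoxy in place of bromo on an aromatic carbon gave a 1.7-fold lower number from compound 1 to compound 2 (0.22 log units; within the scatter). Neither measured compound carries the entering group, so this is weak guidance and the range stays wide. The expected change is a 1.2-fold lower number from compound 2 to compound 3 (0.07 log units; within the scatter), so no clear shift is expected beyond the scatter. For compound 3 the estimate is 1700 nM, with an expected range of 500 nM to 5500 nM.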

Compound 3, half-maximal inhibitory concentration: 800 nM
Compound 3: the middle estimate sits 2.1-fold (0.33 log units) above what was measured; measured number inside the range.
By their numbers in this assay, from the lowest: compound 3; then compounds 2 and 1 (each within the scatter of the next).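

In this assay, within the data shown here, this aromatic ring is the first place where an exchange moves the number beyond the scatter. Putting 3-chloro-4-hydroxyphenyl in place of 2-methoxyphenyl gives a 2.5-fold lower number from compound 2 to compound 3 (0.40 log units; beyond the scatter), and putting it in place of 2-bromophenyl gives a 4.1-fold lower number from compound 1 to compound 3 (0.62 log units; beyond the scatter). No measurement on hand accounts for this change.

From the compounds shown here alone, the entering ring carries chlorine and hydroxy together, so their separate shares stay open. Also open, going by these compounds, is what an amine or a carboxylic acid on this ring would give.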